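The source may hold more compounds than are shown below. What is called first, only, known or untested is meant among the compounds shown, and "the series" means these compounds.

Measured so far in an ADME assay on HEK293 cells (Homo sapiens) for antiproliferative activity, read by MTT assay; a lower number here means a stronger inhibitor, a higher number a weaker inhibitor:
compound 1, `CCNC(=O)c1oc2nc(-c3ccccc3)cc(C(F)(F)F)c2c1N`, gives 70000 nM
compound 2, `Nc1c(C(=O)NC2CCCC2)oc2nc(-c3ccccc3)cc(C(F)(F)F)c12`, gives 85000 nM
compound 3, `CNC(=O)c1oc2nc(-c3ccccc3)cc(C(F)(F)F)c2c1N`, gives 62000 nM

The three measured compounds share one core and differ only in the group on the amide nitrogen. The step of a 1.2-fold higher number from compound 1 to compound 2 (0.08 log units; within the scatter) and the step of a 1.1-fold lower number from compound 1 to compound 3 (0.05 log units; within the scatter) are both within the scatter, and so is a 1.4-fold lower number from compound 2 to compound 3 (0.14 log units; within the scatter); compound 3 therefore stands together with compound 1 and compound 2, and none of the three can be set apart from the others.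

Compound 4, `CNC(=O)c1oc2nc(-c3cccs3)cc(C(F)(F)F)c2c1N`, is the next compound. The change from compound 3 is thiophen-2-yl in place of phenyl on an aromatic carbon. Within the data shown here, no measured step touches this position: all three measured steps sit on the amide nitrogen and all lie within the scatter. Among the measured compounds shown here, nothing among the measured compounds therefore points to a change in this assay beyond the scatter, in either direction, and the expected step is a 1.0-fold lower number from compound 3 to compound 4 (0.01 log units; within the scatter). The estimate for compound 4 in this assay is 60000 nM, with a range from 25000 nM to 140000 nM.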

Compound 4, half-maximal inhibitory concentration: 75000 nM
For compound 4 the middle estimate is 1.3-fold (0.10 log units) below the measured one; measured number inside the range.
By their numbers in this assay, from the lowest: compounds 3, 1, 4 and 2 (each within the scatter of the next).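

Among these compounds, this is the first measured change away from the amide nitrogen, and in this assay thiophen-2-yl on the aromatic carbon next to the ring nitrogen stands level with phenyl: a 1.2-fold higher number from compound 3 to compound 4 (0.08 log units; within the scatter). A five-membered aromatic ring with 1 hetero atom can therefore take the place of a six-membered aromatic ring of carbon only at this position with no step beyond the scatter, as with the changes on the amide nitrogen. Nothing measured here explains this result or bears on it.

The compounds shown leave open whether any other group at this position, such as a pyridine ring, an amine or a short alkyl chain, would give a step beyond the scatter. They also leave open what a methyl group or a nitrile would do in place of the trifluoromethyl group.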